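A ring exchange on compound 1 and its half-life

The source may report more compounds than this note shows. Statements on the series, on what has been measured and on what is new or still open speak of the compounds shown alone.

Measured in an ADME assay on microsomes from liver (Rattus norvegicus) for metabolic stability; on this read-out lower numbers stand for a shorter-lived compound and higher numbers for a longer-lived compound:
- compound 1 `CC(C)C(c1ccc(-c2ccc3cccc(F)c3c2)[nH]c1=O)C1SC(=O)NC1=O` gives 0.76 h
- compound 2 `O=C1NC(=O)/C(=C/C2(c3ccc(-c4ccc5cccc(F)c5c4)[nH]c3=O)CC2)O1` gives > 3 h as a limit
- compound 3 `O=C1NC(=O)/C(=C/C(c2ccccc2)c2ccc(-c3ccc4cccc(F)c4c3)[nH]c2=O)O1` gives > 3 h as a limit

Among the measured compounds shown here, compound 1 stands at 0.76 h, the only true number in this set. The other two entries are limits and not numbers, as the set holds (the limit of > 3 h in this assay, at which 2 of the 3 values shown sit). Compound 4 `CC(C)C(/C=C1/C(=O)NC(=O)N1C)c1ccc(-c2ccc3cccc(F)c3c2)[nH]c1=O` keeps the core of compound 1 and differs in one place: a group of 9 heavy atoms (5 carbon, 2 nitrogen, 2 oxygen; one five-membered non-aromatic ring with 2 hetero atoms) in place of a group of 7 heavy atoms (3 carbon, 1 nitrogen, 2 oxygen, 1 sulfur; one five-membered non-aromatic ring with 2 hetero atoms), on a saturated chain carbon bound to an aromatic carbon and a saturated chain carbon. For the measured compounds named here, no measured pair shows a change of this kind, so the expectation starts from compound 1 at 0.76 h. In this assay an estimated 1.7-fold higher number from compound 1 to compound 4 (0.23 log units; within the scatter) is expected, a step towards longer life that stays within the usual scatter. The estimated half-life of compound 4 is 1.3 h (expected range 0.5 h to 3 h).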

Compound 4, half-life: 1.08 h
Compound 4: middle estimate off by 1.2-fold (0.08 log units), on the high side, and the stated range covers the measured number.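

At this place, on a saturated chain carbon bound to an aromatic carbon and a saturated chain carbon, exchanging the 2,4-dioxo-1,3-thiazolidin-5-yl group for the sulfur-free ring gives a 1.4-fold higher number from compound 1 to compound 4 (0.15 log units; within the scatter) in this assay. Among the compounds shown here, this is the first readable step at this place, and it shows that a ring without sulfur can stand there with a half-life that cannot be told apart from that of the thiazolidine compound. Nothing shown gives a cause for this step.

On these data alone, it remains open whether a carboxylic acid or a primary amide in place of the ring would also stay within the scatter.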